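Swapping the dichlorophenyl ring on the sulfur linker

The source may hold more compounds than are shown below. What is called first, only, known or untested is meant among the compounds shown, and "the series" means these compounds.

Among the compounds with values here, compound 3 `Nc1cc(N)c2nc(-c3ccccc3)c(Sc3ccc(Cl)c(Cl)c3)nc2c1` gives 57500 nM in a functional assay on SNB-19 cells (Homo sapiens) for inhibition, read by sulforhodamine B assay, with a stated time of 48 h (on this read-out higher numbers stand for weaker inhibition of growth and lower numbers for stronger inhibition of growth), the highest of the three numbers measured so far. Compound 1 `Nc1cc(N)c2nc(-c3ccccc3)c(Oc3ccc(Cl)c(Cl)c3)nc2c1` gives 52500 nM, and the gap a 1.1-fold higher number from compound 1 to compound 3 (0.04 log units; within the scatter) sits within the scatter. Compound 2 `Nc1cc(N)c2nc(-c3ccccc3)c(NCc3ccc(F)cc3)nc2c1` gives 20000 nM, and the step of a 2.9-fold higher number from compound 2 to compound 3 (0.46 log units; beyond the scatter) is modest but beyond the scatter. Compound 4 `Nc1cc(N)c2nc(-c3ccccc3)c(Sc3ccc(F)cc3)nc2c1` differs from compound 3 by 4-fluorophenyl in place of 3,4-dichlorophenyl on a sulfur. Within the data shown here, no measured step changes only this ring on the sulfur; the closest guide is a 2.6-fold lower number from compound 1 to compound 2 (0.42 log units; beyond the scatter), where (4-fluorobenzyl)amino replaces 3,4-dichlorophenoxy, though the linking atom changed there too. A modest move toward a lower number, or none beyond the scatter, is therefore expected. Compound 4 is estimated at 35000 nM, with a range from 12000 nM to 100000 nM, meaning an expected step of a 1.6-fold lower number from compound 3 to compound 4 (0.22 log units; within the scatter).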

Compound 4, concentration for total growth inhibition: 41700 nM
Beside the measured number, compound 4's estimate is 1.2-fold (0.08 log units) below it, within the range that was stated.
By their numbers in this assay, from the lowest: compound 2; then compounds 4, 1 and 3 (each within the scatter of the next).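

Changing only the ring on the sulfur gives a 1.4-fold lower number from compound 3 to compound 4 (0.14 log units; within the scatter) in this assay and does not separate the two compounds. With 4-fluorophenyl on the sulfur, a 2.1-fold higher number from compound 2 to compound 4 (0.32 log units; beyond the scatter) remains, while a 1.3-fold lower number from compound 1 to compound 4 (0.10 log units; within the scatter) does not exceed the scatter, so the gap from compound 2 does not depend on the 3,4-dichlorophenyl ring. Nothing measured here explains these steps.

Still open, going by these compounds, is whether a methoxy group or a carboxylic acid on this ring would shift the number. On these data alone, it is also open whether an amine in place of the sulfur link would.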